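The source may hold more compounds than are shown below. What is called first, only, known or untested is meant among the compounds shown, and "the series" means these compounds.

Measured so far:
compound 1, `CCCCCNC(=O)CC1CCc2cc(OC)c(OC)cc21`, in a functional assay on the whole organism (strain Wistar) for inhibition, with Rattus norvegicus as the target, read by paw edema, with stated times of 60 min and 24 h, at a dose of 100 mg/kg by the oral route; on this read-out higher numbers stand for more inhibition at the one dose given (going by the name of the read-out) and lower numbers for less inhibition: 46.7%
compound 2, `COc1cc2c(cc1OC)C(CC(=O)N1CCCCC1)CC2`, in this assay: 40%

Compound 2 sits alongside compound 1 on these numbers; the step of a number 6.7 percentage points lower from compound 1 to compound 2 (within the scatter) lies within the scatter, so nothing separates the two. Compound 3, `COc1cc2c(cc1OC)C(CC(=O)N1CCOCC1)CC2`, is not yet measured in this assay. It differs from compound 2 in one place: morpholin-4-yl in place of piperidin-1-yl on a carbonyl carbon. Going by the values given here, the one measured step that bears on this position is a number 6.7 percentage points lower from compound 1 to compound 2 (within the scatter), an exchange of one amide substituent for another on the same carbonyl carbon, and it did not move the read-out beyond the scatter. Among the compounds with values here, with only that step to go on, the estimated step of a number 2 percentage points lower from compound 2 to compound 3 (within the scatter) in this assay is expected to be none beyond the scatter. Compound 3 is therefore expected to give 38% in this assay, between 25% and 52%.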

Compound 3, a percentage reported as inhibition, in the whole organism at one dose (the size of the read-out at that dose, not a potency): 23.3%
The estimate for compound 3 lay 14.7 percentage points above the measured number; the whole stated range lies above it.
By their numbers in this assay, from the lowest: compound 3; then compounds 2 and 1 (each within the scatter of the next).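

The amide substituent on the carbonyl carbon is not indifferent in this assay: morpholin-4-yl in place of piperidin-1-yl gives a number 16.7 percentage points lower from compound 2 to compound 3 (beyond the scatter), although the two groups are six-membered rings of equal heavy-atom count and differ in the oxygen of morpholin-4-yl. Morpholin-4-yl in place of pentylamino gives a number 23.4 percentage points lower from compound 1 to compound 3 (beyond the scatter), whereas piperidin-1-yl in place of pentylamino stayed within the scatter, so among these three amides the position separates only morpholin-4-yl from the other two. Nothing available on these compounds accounts for this difference.

As far as these compounds go, it remains open whether the loss follows the ring oxygen specifically or would also appear with thiomorpholin-4-yl or piperazin-1-yl at this carbonyl carbon. The single dose also leaves open whether the step would hold at other doses of compound 3.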